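Phenyl in place of pyrimidinyl on the sulfonamide nitrogen

The compounds below may be only part of what the source reports. "The series", "measured", "known", "first", "only" and "open" are said of these compounds alone.

Compound 1 `O=C(Nc1ccc(S(=O)(=O)Nc2ccccc2)cc1)c1cc(F)c(Cl)cc1F` gives 37% in a functional assay on HEK293 cells for agonist activity at probable G-protein coupled receptor 27 (Homo sapiens), read by a luciferase reporter and beta-arrestin recruitment, with a stated time of 10 min; a higher number here means a larger maximal response, a lower number a smaller maximal response.
Compound 2 `O=C(Nc1ccc(S(=O)(=O)Nc2ncccn2)cc1)c1ccc(Cl)cc1Cl` gives "not determined" (no result reported) in this assay.

Among the compounds with values here, compound 2 stands without a number: its result in this assay was not reported, so no step can be measured from it. Compound 3 `O=C(Nc1ccc(S(=O)(=O)Nc2ccccc2)cc1)c1ccc(Cl)cc1Cl` differs from compound 2 by phenyl in place of pyrimidin-2-yl on a sulfonamide nitrogen. With compound 2 unmeasured, the size and direction of this step in this assay cannot be read from the data. Compound 1 also carries the anilino sulfonamide and gives 37% in this assay, so a maximal response of similar size is expected for compound 3. Compound 3 is estimated at 40%, within 15% to 70%.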

Compound 3, largest response reached (Emax), in percent of the reference or control that the assay uses: 100%
Beside the measured number, compound 3's estimate is 60 percentage points below it, and the stated range ends below it.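

With the anilino sulfonamide common to both compounds, the group on the carbonyl carbon proves decisive in this assay: 2,4-dichlorophenyl in place of 4-chloro-2,5-difluorophenyl gives a number 63 percentage points higher from compound 1 to compound 3 (beyond the scatter). Phenyl on the sulfonamide nitrogen is thus compatible with a large maximal response, as compound 3 reaches 100%. Nothing available explains this gain.

Going by these compounds, the step between pyrimidin-2-yl and phenyl cannot be read, so the effect of that exchange remains unknown. Also open, on these data alone, is how a pyridin-2-yl or cyclohexyl group on the sulfonamide nitrogen would compare.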